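Fluoro for Hydrogen Tried Again on a Weaker Core

The source may report more compounds than this note shows. Statements on the series, on what has been measured and on what is new or still open speak of the compounds shown alone.

Compound 3 `O=C(Nc1cc(C(F)(F)F)cc(C(F)(F)F)c1)c1cc(Br)ccc1O` is the stronger of the two closely related compounds measured here. In a functional assay on KG-1 cells (Homo sapiens) for cytotoxicity, read by luminescence and CellTiter-Glo, with a stated time of 3 days (a higher number here means a weaker inhibitor, a lower number a stronger inhibitor), compound 3 gives 300 nM. Compound 1 `O=C(Nc1cc(C(F)(F)F)cc(C(F)(F)F)c1)c1cc(Br)c(F)cc1O` differs from it by one change, (fluoro in place of hydrogen on an aromatic carbon), and in this assay compound 1 gives 510 nM. The step is a 1.7-fold higher number from compound 3 to compound 1 (0.23 log units; within the scatter), so the two values cannot be ranked against each other.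

Compound 2 `N#Cc1ccc(NC(=O)c2ccccc2O)cc1` has a different core; the difference between the two cores is not broken down here. In this assay compound 2 gives 5370 nM, the highest number of the three, and its distance to both compound 1 and compound 3 lies beyond the scatter.

Compound 4 `N#Cc1ccc(NC(=O)c2ccc(F)cc2O)cc1` has not been measured. It differs from compound 2 by fluoro in place of hydrogen on an aromatic carbon. For the measured compounds named here, this is the same kind of change as the one from compound 3 to compound 1, but the surroundings of the place are not identical: in compound 1 the entering fluoro sits ortho to a bromo group, whereas in compound 4 no bromo group is present. Going by the values given here, the only guide is the earlier step, which shows no effect outside the scatter. The step one expects is a 1.2-fold higher number from compound 2 to compound 4 (0.08 log units; within the scatter), because the same kind of change gave a 1.7-fold higher number from compound 3 to compound 1 (0.23 log units; within the scatter). Compound 4 is therefore expected to give 6500 nM, within a range from 2700 nM to 16000 nM.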

Compound 4, half-maximal inhibitory concentration: 3150 nM
Beside the measured number, compound 4's estimate is 2.1-fold (0.31 log units) above it, within the range that was stated.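

The new step in this assay is a 1.7-fold lower number from compound 2 to compound 4 (0.23 log units; within the scatter) and so, like the earlier step, it does not allow its two compounds to be ranked against each other. Read alone, neither step shows an effect of fluoro in place of hydrogen on its own core, yet set side by side the two steps run in opposite directions and do not agree: the same change on two cores in this assay, a 1.7-fold higher number (0.23 log units; within the scatter) from compound 3 to compound 1 and a 1.7-fold lower number (0.23 log units; within the scatter) from compound 2 to compound 4, 2.9-fold (0.46 log units) apart, beyond the scatter of two such steps. This shows that the step seen on the core of compound 1 did not carry over unchanged to the core of compound 4, but it does not show what lies behind the gap: the two cores differ in more than one place, the bromo group among them, and one pair on each core cannot tell which of those differences matters.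

The compounds shown leave open whether the gap between the steps would return on a third core, or with chloro or methoxy entering in the same place. They also leave open how either core would respond if an amine stood in place of the hydroxy group.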